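Rearranging a Piperazine Substituent in a Chemokine Receptor Antagonist Series

This account rests on a few compounds, and the source may have more. Where it says the series, first, only, none or still open, it means among the compounds named here.

Of the compounds shown here, three sharing one core have been tested in a functional assay on CCRF-CEM cells for antagonist activity at C-X-C chemokine receptor type 4 (Homo sapiens), read by calcium flux, with stated times of 25 min and 90 s; a lower number here means a stronger inhibitor, a higher number a weaker inhibitor. Compound 1 `CN(C[C@H]1Cc2c(cccc2N2CCN(C3CC3)CC2)CN1)[C@H]1CCCc2cccnc21` gives 23.5 nM. Compound 2 `c1cnc2c(c1)CCC[C@@H]2N(CC1CC1)C[C@H]1Cc2c(cccc2N2CCNCC2)CN1` gives 26.7 nM, and compound 3 `Cc1cnc2c(c1)CCC[C@@H]2N(C)C[C@H]1Cc2c(cccc2N2CCNCC2)CN1` gives 16.1 nM. All three numbers lie within the usual scatter of one another, so compound 1 cannot be told apart from either neighbour, and none of the three can be called the strongest or weakest.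

Compound 4 `CN(C[C@H]1Cc2c(cccc2N2CCN3CCC[C@H]3C2)CN1)[C@H]1CCCc2cccnc21` has not yet been measured in this assay. It carries the same atoms as compound 1, joined differently: a group of 9 heavy atoms (7 carbon, 2 nitrogen; one five-membered non-aromatic ring with 1 hetero atom, one six-membered non-aromatic ring with 2 hetero atoms) in place of a group of 9 heavy atoms (7 carbon, 2 nitrogen; one three-membered non-aromatic ring of carbon only, one six-membered non-aromatic ring with 2 hetero atoms), on an aromatic carbon The change sits on an aromatic carbon of a six-membered aromatic ring of carbon only, part of a fused system of two rings. Among the compounds with values here, no pair of measured compounds shows this kind of rearrangement, so nothing in the data sets its size or direction. Because the three measured compounds bracket a narrow band around 23.5 nM, the step of a 1.1-fold higher number from compound 1 to compound 4 (0.03 log units; within the scatter) is expected to stay within the scatter. Compound 4 is therefore estimated at 25 nM, with a range from 8 nM to 80 nM.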

Compound 4, half-maximal inhibitory concentration: 2.92 nM
Compound 4: the middle estimate sits 8.6-fold (0.93 log units) above what was measured, and the stated range ends above it.
By their numbers in this assay, from the lowest: compound 4; then compounds 3, 1 and 2 (each within the scatter of the next).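

Replacing the 4-cyclopropylpiperazin-1-yl group on the aromatic carbon with a group built from the same atoms, now joined as a five-membered and a six-membered non-aromatic ring, gives an 8.0-fold lower number from compound 1 to compound 4 (0.91 log units; beyond the scatter) in this assay. The two groups have the same heavy atoms, the same counts of hydrogen-bond donors and acceptors, and no net charge, so at this position the way the atoms are joined can move the number beyond the scatter, something the three earlier compounds, all within the scatter of one another, could not show. No supporting measurement is available to explain this step.

From the compounds shown here alone, what remains open is whether the mirror-image arrangement at the defined stereocentre of the new group would give a similar number. Going by these compounds, it is also open how a larger fused ring, or an open-chain 4-isopropylpiperazin-1-yl group, would behave at this position.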